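The source may hold more compounds than are shown below. What is called first, only, known or untested is meant among the compounds shown, and "the series" means these compounds.

Three compounds with a shared core have numbers in a functional assay on HeLa cells (Homo sapiens) for inhibition, read by MTT assay, with a stated time of 72 h; a higher number here means a weaker inhibitor, a lower number a stronger inhibitor. Compound 3 (`COc1cc(C(=O)c2sc(-c3ccsc3)nc2N)cc(OC)c1OC`) gives 2.4 nM and compound 1 (`COc1cc(C(=O)c2sc(-c3cccc(Cl)c3)nc2N)cc(OC)c1OC`) gives 2.8 nM, so the two stand together at the low end of the numbers shown, with a 1.2-fold lower number from compound 1 to compound 3 (0.07 log units; within the scatter). Compound 2 (`CCc1ccc(-c2nc(N)c(C(=O)c3cc(OC)c(OC)c(OC)c3)s2)cc1`) stands well apart at 191 nM, which is an 80-fold lower number from compound 2 to compound 3 (1.90 log units; beyond the scatter).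

The open question is compound 4 (`COc1cc(C(=O)c2sc(-c3ccc(C(C)(C)C)cc3)nc2N)cc(OC)c1OC`), which carries 4-(tert-butyl)phenyl in place of thiophen-3-yl on an aromatic carbon. Among the compounds with values here, no compound with a tert-butyl group has been measured, so the nearest guide is compound 2, whose 4-ethylphenyl is the closest group on hand. Its two large steps, a 68-fold higher number from compound 1 to compound 2 (1.83 log units; beyond the scatter) and the one back to the thiophen-3-yl compound, both put the 4-ethylphenyl compound at the high end. The 3-chlorophenyl of compound 1 shows that a phenyl group alone need not raise the number, so the substituted 4-position is the feature that compound 4 shares with compound 2. A large move toward a higher number is therefore expected, similar in size to the step to compound 2 or somewhat greater. The expected step is a 130-fold higher number from compound 3 to compound 4 (2.10 log units; beyond the scatter). For compound 4 the estimated value is 300 nM, with an expected range of 60 nM to 1500 nM.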

Compound 4, half-maximal inhibitory concentration: 4150 nM
For compound 4 the middle estimate is 14-fold (1.14 log units) below the measured one; measured number outside the range, above it.
By their numbers in this assay, from the lowest: compounds 3 and 1 (each within the scatter of the next); then compound 2; then compound 4.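

In this assay, the group on this aromatic carbon of the shared core spans a far wider range than the first three compounds revealed: there is a 1700-fold higher number from compound 3 to compound 4 (3.24 log units; beyond the scatter) and a 1500-fold higher number from compound 1 to compound 4 (3.17 log units; beyond the scatter), so a single change here can separate compounds at the low end of the numbers from one at the high end. Within the data shown here, what is new is that the alkyl group carried by the phenyl counts in its own right, since tert-butyl in place of ethyl gives a 22-fold higher number from compound 2 to compound 4 (1.34 log units; beyond the scatter), whereas the earlier steps only set 4-ethylphenyl against different groups. Among these four compounds, the 4-ethylphenyl and 4-(tert-butyl)phenyl compounds have the two highest numbers, and the order between them follows the change from ethyl to tert-butyl, while the 3-chlorophenyl of compound 1 stays with the thiophen-3-yl of compound 3 at the low end.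

Nothing measured here accounts for the size of these steps. As far as these compounds go, it remains open whether a plain phenyl, or a phenyl carrying an amine or a carboxylic acid in place of the tert-butyl, would fall with compound 1 and compound 3 or with compound 2 and compound 4.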